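Chain amine swap at the assay limit

A few compounds are considered here, and "the series" means these few. Any claim that something is new, unique, unknown or untested is made for them only; others in the source may bear on it.

In a functional assay on DU-145 cells (Homo sapiens) for cytotoxicity, read by MTT assay, with stated times of 48 h and 4 h (a lower number here means a stronger inhibitor, a higher number a weaker inhibitor), the measured compounds are these
compound 1 `O=[N+]([O-])c1ccc(/C=C/c2nc(NCCN3CCCCC3)c3ccccc3n2)cc1` gives > 100000 nM as a limit
compound 2 `CC(C)N(CCNc1nc(/C=C/c2ccc([N+](=O)[O-])cc2)nc2ccc(Cl)cc12)C(C)C` gives > 100000 nM as a limit

Compound 2 stands at the limit of > 100000 nM in this assay, at which 2 of the 2 values shown sit, so it has a limit and no number. Compound 3 `O=[N+]([O-])c1ccc(/C=C/c2nc(NCCN3CCCCC3)c3cc(Cl)ccc3n2)cc1` is not yet measured. It carries piperidin-1-yl in place of diisopropylamino on a saturated chain carbon, two bonds along the chain from a nitrogen on an aromatic ring. Going by the values given here, with no measured step to go on, the estimated step of a number no higher from compound 2 to compound 3 (the limit leaves the size open) is expected to stay within the scatter in this assay, with no direction. Compound 3 is expected at 100000 nM, with an estimated range of 30000 nM to 150000 nM, and probably again as a limit.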

Compound 3, half-maximal inhibitory concentration: > 100000 nM
Compound 3: only a limit was reported; the forecaster's own chance of this, stated with the estimate: 75%; the middle value lies on the limit itself.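

No step can be read from compound 2 to compound 3 or from compound 1 to compound 3, because each pair has only limits: the limit of > 100000 nM in this assay, at which 3 of the 3 values shown sit.

From the compounds shown here alone, whether piperidin-1-yl for diisopropylamino, or chloro for hydrogen, changes anything in this assay stays open.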